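Swapping Fluoro for Bromo on a Growth Inhibitor

The compounds below may be only part of what the source reports. "The series", "measured", "known", "first", "only" and "open" are said of these compounds alone.

In a functional assay on cells (Panel NCI-60 (60 carcinoma cell lines), Homo sapiens) for inhibition, read by sulforhodamine B assay, with a stated time of 48 h (on this read-out lower numbers stand for stronger inhibition of growth and higher numbers for weaker inhibition of growth), compound 3 `CN(c1ccc(F)cc1)S(=O)(=O)c1ccc(-c2cnc(C3CC3)o2)cc1` gives 1180 nM. That lies within the scatter of compound 1 `O=S(=O)(Nc1ccc2ccccc2c1)c1ccc(-c2cnc(C3CC3)o2)cc1` at 1840 nM, and it is a lower number than compound 2 `O=S(=O)(Nc1ccc(Br)cc1)c1ccc(-c2cnc(C3CC3)o2)cc1` at 2750 nM, a gap beyond the scatter. Compound 4 `CN(c1ccc(Br)cc1)S(=O)(=O)c1ccc(-c2cnc(C3CC3)o2)cc1` differs from compound 3 in one place: bromo in place of fluoro on an aromatic carbon. Within the data shown here, no pair of measured compounds shows this swap alone, so any forecast is uncertain. The expected change is small, a 1.3-fold higher number from compound 3 to compound 4 (0.10 log units; within the scatter), within the scatter. It leans towards a higher number because the bromo-bearing compound 2 gives 2750 nM. For compound 4 the estimated value is 1500 nM, with an expected range of 700 nM to 3200 nM.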

Compound 4, concentration for 50% growth inhibition: 3920 nM
Beside the measured number, compound 4's estimate is 2.6-fold (0.42 log units) below it; the measured number lies above the stated range.
By their numbers in this assay, from the lowest: compounds 3, 1, 2 and 4 (each within the scatter of the next, the first and the last beyond it).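

Swapping 4-fluorophenyl for 4-bromophenyl gives a 3.3-fold higher number from compound 3 to compound 4 (0.52 log units; beyond the scatter) in this assay, the first direct sign that the halogen at this place matters. With bromo present, methyl in place of hydrogen on the sulfonamide nitrogen gives a 1.4-fold higher number from compound 2 to compound 4 (0.15 log units; within the scatter) and so has no clear effect on the number. Nothing available explains the gain in number on going to bromo.

On these data alone, whether chloro or an amine at this place would follow fluoro or bromo stays open. So does the effect of the sulfonamide methyl when fluoro is present.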